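A few compounds are considered here, and "the series" means these few. Any claim that something is new, unique, unknown or untested is made for them only; others in the source may bear on it.

Working notes on the series. The shared core is carried by compound 1 `O=C(N/N=C/c1c(-c2cc3ccccc3oc2=O)[nH]c2ccccc12)c1ccccc1F`, compound 2 `O=C(N/N=C/c1c(-c2cc3ccccc3oc2=O)[nH]c2ccccc12)c1cccc(Br)c1` and compound 3 `O=C(N/N=C/c1c(-c2cc3ccccc3oc2=O)[nH]c2ccccc12)c1ccc(Cl)cc1F`, which differ only in the aryl group on the carbonyl carbon. In a functional assay on MCF7 cells (Homo sapiens) for inhibition, read by MTT assay, with a stated time of 48 h (a lower number here means a stronger inhibitor, a higher number a weaker inhibitor), compound 1 gives only a limit, > 200000 nM. In this assay compound 2 likewise gives only a limit, > 200000 nM. In this assay compound 3 also gives only a limit, > 200000 nM. Compound 2 thus stands at the assay limit together with the two other values shown, all three sitting at the limit of > 200000 nM in this assay, at which 3 of the 3 values shown sit.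

The measured steps are a step that the two limits leave unreadable from compound 1 to compound 2, a step that the two limits leave unreadable from compound 1 to compound 3 and a step that the two limits leave unreadable from compound 2 to compound 3; none has a readable size, both ends being limits.

Compound 4 `O=C(N/N=C/c1c(-c2cc3ccc(Br)cc3oc2=O)[nH]c2ccccc12)c1cccc(Br)c1` differs from compound 2 by bromo in place of hydrogen on an aromatic carbon, on a six-membered aromatic ring of carbon only within the fused two-ring system, meta to a fused ring and para to a fused ring. Going by the values given here, no measured step touches this position, and no measured step yields a readable size at all. The expected step from compound 2 to compound 4 is therefore a step that the limit leaves unreadable from compound 2 to compound 4, with no movement off the limit foreseen. Compound 4 is estimated at 400000 nM, expected between 150000 nM and 2000000 nM, most likely again reported as a limit.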

Compound 4, half-maximal inhibitory concentration: > 200000 nM
Compound 4: only a limit was reported; the forecaster's own chance of this, stated with the estimate: 85%; the middle value does not contradict the limit.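

In this assay compound 4 gives only a limit, > 200000 nM, so no size can be read for its step from compound 2, which is also known only as a limit. The compounds shown leave open whether any of these changes moves the value at all: the limit of > 200000 nM in this assay, at which 4 of the 4 values shown sit.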